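Replacing a nitrile with a phenoxy group on the benzyl ring

The source may hold more compounds than are shown below. What is called first, only, known or untested is meant among the compounds shown, and "the series" means these compounds.

Of the compounds shown here, three sharing one core have been tested in a functional assay for agonist activity at Free fatty acid receptor 1 (Homo sapiens); on this read-out higher numbers stand for an effect only at larger amounts of compound and lower numbers for an effect already at smaller amounts. Compound 1 `Cc1ccc(CNc2ccc(CCC(=O)O)cc2)cc1` carries a methyl group on the outer aromatic ring and gives 3980 nM. Compound 2 `O=C(O)CCc1ccc(NCc2ccccc2)cc1` has hydrogen in that place, and in this assay compound 2 gives 7940 nM; the change a 2.0-fold higher number from compound 1 to compound 2 (0.30 log units; within the scatter). Compound 3 `N#Cc1ccc(CNc2ccc(CCC(=O)O)cc2)cc1` carries a cyano group there. For compound 3 this assay reports only a limit, < 31700 nM, so no number is known and compound 3 stands at the edge of what was measured, as noted in the limit of < 31700 nM in this assay, at which 1 of the 3 values shown sits. The steps from compound 1 and from compound 2 to compound 3 cannot be sized for this reason.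

Compound 4 `O=C(O)CCc1ccc(NCc2ccc(Oc3ccccc3)cc2)cc1` differs from compound 3 by phenoxy in place of cyano on an aromatic carbon. Going by the values given here, no measured step shows a phenoxy group, so the expectation rests only on the fact that compound 3 sits at a limit. Compound 4 is expected to return into the measurable range, a step that the limit leaves unreadable from compound 3 to compound 4. The estimate for compound 4 in this assay is 1000 nM, expected to lie between 200 nM and 8000 nM.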

Compound 4, half-maximal effective concentration: 195 nM
Compound 4: middle estimate off by 5.1-fold (0.71 log units), on the high side; measured number outside the range, below it.
By their numbers in this assay, from the lowest: compound 4; then compounds 1 and 2 (each within the scatter of the next).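

At this place on the ring, the larger phenoxy group is accepted in this assay and brings a clear gain (a 41-fold lower number from compound 2 to compound 4 (1.61 log units; beyond the scatter)) and (a 20-fold lower number from compound 1 to compound 4 (1.31 log units; beyond the scatter)). Methyl and hydrogen lie within the scatter of each other, so only this change shows that the group here can move the number by a large margin. The steps to compound 4 from compound 3 cannot be read, and no size can be given for the nitrile-to-phenoxy change, because compound 3 is known only through a limit: the limit of < 31700 nM in this assay, at which 1 of the 4 values shown sits.

The compounds shown leave open whether the oxygen of the phenoxy group matters, which a phenyl or benzyloxy group at this place would help to tell. Also open, as far as these compounds go, is how a chlorine atom or a methoxy group on the added ring would move the number.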